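Swapping an Isopentyl Chain for a Difluorophenyl Ring

The compounds below may be only part of what the source reports. "The series", "measured", "known", "first", "only" and "open" are said of these compounds alone.

Three measured compounds share one core and differ in what sits on a carbonyl carbon whose other neighbour is an amide-type nitrogen. Compound 1 `CC(C)CCC(=O)N[C@@H](C(=O)N1CCC(c2ccc(Cl)cc2)CC1)C(C)C` carries an isopentyl chain there, and in an assay on THP-1 cells for displacement of a labelled ligand from C-C chemokine receptor type 1 (Homo sapiens) (on this read-out lower numbers stand for stronger inhibition and higher numbers for weaker inhibition), compound 1 gives 26 nM. Compound 2 `Cc1ccccc1C(=O)NC(CC(C)C)C(=O)N1CCC(c2ccc(Cl)cc2)CC1` carries an aromatic ring on that carbon and also a different side chain; in this assay compound 2 gives 88 nM. Compound 3 `CC(C)C(=O)NC(C(=O)N1CCC(c2ccc(Cl)cc2)CC1)C(C)C` carries a smaller branched group; in this assay compound 3 gives 388 nM. Among these three numbers compound 1 has the lowest. The nearest is compound 2, whose number lies higher by more than the usual scatter, and the furthest is compound 3, whose number lies higher still.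

Going by the values given here, the untested compound 4 `CC(C)[C@@H](NC(=O)c1ccc(F)c(F)c1)C(=O)N1CCC(c2ccc(Cl)cc2)CC1` keeps the core and side chain of compound 1 and changes only that group: 3,4-difluorophenyl in place of isopentyl on a carbonyl carbon. An aromatic ring on this carbon looks tolerable, because compound 2 gives 88 nM with one. The step from compound 1 to compound 4 is therefore expected to be modest, toward a somewhat higher number, a 2.1-fold higher number from compound 1 to compound 4 (0.33 log units; beyond the scatter). Compound 4 is estimated at 55 nM, with a range from 15 nM to 200 nM.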

Compound 4, half-maximal inhibitory concentration: 14 nM
Compound 4: middle estimate off by 3.9-fold (0.59 log units), on the high side; the whole stated range lies above it.
By their numbers in this assay, from the lowest: compounds 4 and 1 (each within the scatter of the next); then compound 2; then compound 3.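

In this assay, exchanging the isopentyl chain for a 3,4-difluorophenyl ring gives a 1.9-fold lower number from compound 1 to compound 4 (0.27 log units; within the scatter), and on this read-out the two compounds cannot be told apart. Going by these compounds alone, compound 2 also carries an aromatic ring on this carbon, but it differs from compound 1 in its side chain as well, which leaves the contribution of the ring alone unclear; compound 4 removes that ambiguity by keeping the core and side chain of compound 1 and changing only this group, showing that an open five-carbon chain and a fluorinated aromatic ring can serve equally well here in this assay. Nothing measured here explains why two such different groups give matching results.

On these data alone, whether the fluorine atoms contribute at all remains open, and a plain phenyl ring or a phenyl ring with a single fluorine on the same carbonyl carbon would separate the effect of the ring from that of its fluorines. Also open, as far as these compounds go, is how a pyridine ring, which puts a nitrogen into the ring, or a chain longer than isopentyl would fare at this position.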